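This account rests on a few compounds, and the source may have more. Where it says the series, first, only, none or still open, it means among the compounds named here.

In a functional assay on HeLa cells (Homo sapiens) for antiproliferative activity, read by MTT assay, with a stated time of 72 h (a higher number here means a weaker inhibitor, a lower number a stronger inhibitor), every reading so far is a limit and not a number. Compound 1, `CCCn1ccnc1-c1cc(OC)c(OC)c(OC)c1`, gives > 100000 nM, which is a limit. Compound 2, `CCCCCn1ccnc1-c1cc(OC)c(OC)c(OC)c1`, gives > 100000 nM, also a limit. Compound 3, `COc1cc(-c2nccn2Cc2ccccc2)cc(OC)c1OC`, gives > 100000 nM, again a limit. Compound 3 thus stands at the limit of > 100000 nM in this assay, at which 3 of the 3 values shown sit. Compound 4, `COc1cc(-c2nccn2-c2ccc(C)cc2)cc(OC)c1OC`, has 4-methylphenyl in place of benzyl on an aromatic nitrogen. Among the measured compounds shown here, the steps that bear on this change its substituent on that same nitrogen, yet none has a readable size: a step that the two limits leave unreadable from compound 1 to compound 2, a step that the two limits leave unreadable from compound 1 to compound 3 and a step that the two limits leave unreadable from compound 2 to compound 3. Only a tentative shift toward stronger inhibition is therefore expected, and another limit remains likely, with an estimated at least 1.6-fold lower number from compound 3 to compound 4 (0.22 log units; that floor lies within the scatter). Compound 4 is expected at 60000 nM, within an estimated range of 8000 nM to 150000 nM.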

Compound 4, half-maximal inhibitory concentration: 700 nM
For compound 4 the middle estimate is 86-fold (1.93 log units) above the measured one; the whole stated range lies above it.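

The substituent on this aromatic nitrogen can decide activity in this assay: 4-methylphenyl in place of benzyl, the same atoms joined differently, gives an at least 140-fold lower number from compound 3 to compound 4 (2.15 log units; beyond the scatter). The same group gives an at least 140-fold lower number from compound 2 to compound 4 (2.15 log units; beyond the scatter) in place of pentyl and an at least 140-fold lower number from compound 1 to compound 4 (2.15 log units; beyond the scatter) in place of propyl. The steps among compound 1, compound 2 and compound 3 cannot be read, and only compound 4 leaves the limit: the limit of > 100000 nM in this assay, at which 3 of the 4 values shown sit.

The compounds shown leave open whether the methyl group is needed, since an unsubstituted phenyl does not appear among them. On these data alone, a 4-methoxyphenyl or 4-chlorophenyl group on this nitrogen also remains open.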